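A few compounds are considered here, and "the series" means these few. Any claim that something is new, unique, unknown or untested is made for them only; others in the source may bear on it.

In a functional assay on HepG2 cells (Homo sapiens) for inhibition, read by scintillation counting, with a stated time of 2 h (a lower number here means a stronger inhibitor, a higher number a weaker inhibitor), compound 1 `CCNC(=O)Nc1sc2ccccc2c1C(=O)N1CCN(C2CCN(C(=O)C3CCCC3)CC2)CC1` gives 309 nM, and compound 2 `CCNC(=O)Nc1sc2ccccc2c1C(=O)N1CCN(C2CCN(C(=O)C(C)(C)C)CC2)CC1` gives 450 nM. Compound 3 `CCNC(=O)Nc1sc2ccccc2c1C(=O)N1CCN(C2CCN(C(=O)OC)CC2)CC1`, which shares their core, has no number to stand on: its entry reads "not determined" (no result reported), so it offers no starting value. Compound 4 `CCNC(=O)Nc1sc2ccccc2c1C(=O)N1CCN(C2CCN(C(=O)OCC)CC2)CC1` differs from compound 3 by methyl in place of hydrogen on a saturated chain carbon bound to an oxygen next to a carbonyl group, which turns methoxycarbonyl into ethoxycarbonyl. Within the data shown here, only one measured step bears on this change, and only loosely, since it concerns other groups on the same carbonyl position: tert-butyl in place of cyclopentyl on a carbonyl carbon gives a 1.5-fold higher number from compound 1 to compound 2 (0.16 log units; within the scatter). With that step within the scatter, no step beyond the scatter is expected for this small addition in this assay. Without a value for compound 3, the expectation has to lean on the values of the two measured compounds, and the range stays wide. The estimated value for compound 4 is 420 nM, with an expected range from 150 nM to 1200 nM.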

Compound 4, half-maximal inhibitory concentration: 228 nM
Compound 4: middle estimate off by 1.8-fold (0.27 log units), on the high side; low and high end bracket the measured number.
By their numbers in this assay, from the lowest: compounds 4, 1 and 2 (each within the scatter of the next).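

In this assay, ethoxy on the carbonyl carbon joins cyclopentyl and tert-butyl with no separation beyond the scatter: a 2.0-fold lower number from compound 2 to compound 4 (0.30 log units; within the scatter), and a 1.4-fold lower number from compound 1 to compound 4 (0.13 log units; within the scatter). Across these three compounds, this position therefore accepts a group attached through oxygen as well as groups attached through carbon, with the numbers staying within the scatter of one another. The step from compound 3 to compound 4 cannot be read, as compound 3 has no reported result.

On these data alone, what the added methyl contributes on its own thus remains open. Also open, as far as these compounds go, is whether a longer chain such as propoxy, or an amine on the same carbonyl carbon, would stay in this range, and no measurement at hand accounts for these values.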